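Cyano in Place of Phenyl on a Shared Indole Core

A few compounds are considered here, and "the series" means these few. Any claim that something is new, unique, unknown or untested is made for them only; others in the source may bear on it.

Compound 1: `Brc1ccc2[nH]c(-c3cncn3Cc3ccc(-c4ccccc4)cc3)cc2c1` gives 3090 nM
Compound 2: `Cc1ccc(Cn2cncc2-c2cc3cc(Br)ccc3[nH]2)cc1` gives 4290 nM

Both compounds were tested in an assay on HEK293 cells for inhibition of Indoleamine 2,3-dioxygenase 1 (Homo sapiens), with a stated time of 30 min; a lower number here means that less compound is needed, a higher number that more compound is needed for the effect. Compound 1 has the lowest of the two numbers, and its nearest neighbour is compound 2, separated by a 1.4-fold higher number from compound 1 to compound 2 (0.14 log units; within the scatter). Since that step lies within the scatter, the two compounds cannot be ordered.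

Compound 3 is `N#Cc1ccc(Cn2cncc2-c2cc3cc(Br)ccc3[nH]2)cc1`, not yet measured. It differs from compound 1 in one place: cyano in place of phenyl on an aromatic carbon. Among the measured compounds shown here, the only measured step that bears on this position is the one from compound 1 to compound 2, which replaced the same phenyl with methyl and moved the number by a 1.4-fold higher number from compound 1 to compound 2 (0.14 log units; within the scatter), within the scatter. For the measured compounds named here, no measured step involves cyano itself, so the expectation rests on that single comparison. Compound 3 is therefore expected to show a 1.3-fold higher number from compound 1 to compound 3 (0.11 log units; within the scatter), a change not clearly beyond the scatter. The estimated value for compound 3 is 4000 nM, with a range from 1500 nM to 12000 nM.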

Compound 3, half-maximal effective concentration: 6920 nM
Compound 3: the middle estimate sits 1.7-fold (0.24 log units) below what was measured; measured number inside the range.
By their numbers in this assay, from the lowest: compounds 1, 2 and 3 (each within the scatter of the next, the first and the last beyond it).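

In this assay, among the compounds shown here, cyano in place of phenyl gives a 2.2-fold higher number from compound 1 to compound 3 (0.35 log units; beyond the scatter) and so provides the first step at this position that lies beyond the scatter, though only modestly. Cyano in place of methyl gives a 1.6-fold higher number from compound 2 to compound 3 (0.21 log units; within the scatter) and stays within the scatter, so these two small groups cannot be ordered, and phenyl is separated from cyano but not from methyl. No measurement shown here explains why replacing phenyl with cyano moves the number.

For the compounds shown here, with only three groups at this position, it remains open how an amine, a carboxylic acid or a longer chain would compare. It is also unclear whether another six-membered aromatic ring carrying a substituent of its own would match phenyl or fall nearer cyano.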